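The source may hold more compounds than are shown below. What is called first, only, known or untested is meant among the compounds shown, and "the series" means these compounds.

Among the compounds with values here, in a functional assay on DU-145 cells (Homo sapiens) for cytotoxicity, read by MTT assay (a lower number here means a stronger inhibitor, a higher number a weaker inhibitor), compound 2 `CCCC(C)(O)CC(=O)O[C@H](CC=C(C)C)C1=CC(=O)c2c(O)ccc(O)c2C1=O` gives 75000 nM, the only true number so far. Compound 1 `CCCCCCC(C)(O)CC(=O)O[C@H](CC=C(C)C)C1=CC(=O)c2c(O)ccc(O)c2C1=O` gives > 100000 nM, which is a limit of the assay and not a number. Within the data shown here, the single measured step, an at least 1.3-fold lower number from compound 1 to compound 2 (0.12 log units; that floor lies within the scatter), stays within the scatter, and its size is tied to the limit of > 100000 nM in this assay, at which 1 of the 2 values shown sits, so it shows no clear trend.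

Compound 3 `CC(C)=CC[C@@H](OC(=O)C1CCCCO1)C1=CC(=O)c2c(O)ccc(O)c2C1=O` brings a larger change: oxan-2-yl in place of 2-hydroxy-2-methylpentyl on a carbonyl carbon. In words, this is oxan-2-yl in place of 2-hydroxy-2-methylpentyl on a carbonyl carbon. The open chain, with its hydroxyl group, gives way to a ring. Among the measured compounds shown here, no measured pair covers this exchange, and the one step available concerns only the length of the chain, so it offers weak guidance.

For the measured compounds named here, with compound 2 at 75000 nM, the numbers so far leave more room for a lower value than for a higher one. A modest move towards a stronger inhibitor is therefore expected, and the estimated step is a 1.7-fold lower number from compound 2 to compound 3 (0.22 log units; within the scatter), with wide uncertainty. For compound 3 the estimated value is 45000 nM, with an expected range from 10000 nM to 100000 nM.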

Compound 3, half-maximal inhibitory concentration: 24700 nM
Compound 3: the middle estimate sits 1.8-fold (0.26 log units) above what was measured; the measured number falls inside the stated range.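

In this assay, within the data shown here, putting oxan-2-yl in place of 2-hydroxy-2-methylpentyl on a carbonyl carbon gives a 3.0-fold lower number from compound 2 to compound 3 (0.48 log units; beyond the scatter) and so provides the first measured step here that clearly exceeds the scatter, showing that the group at this position can change the result. Compound 1 gives > 100000 nM as a limit of the assay and not a true number. Against that limit, the same kind of exchange gives an at least 4.0-fold lower number from compound 1 to compound 3 (0.60 log units; beyond the scatter) as a floor only, so the full size of this step remains unknown: the limit of > 100000 nM in this assay, at which 1 of the 3 values shown sits.

The exchange closes an open chain into a ring and also replaces a group with a hydrogen-bond donor by one with none, so these compounds cannot separate the effect of the ring from the effect of losing the hydroxyl. As far as these compounds go, it also remains open how the result would shift with a cyclohexyl ring, which has no ring oxygen, with an open chain lacking the hydroxyl, or with a six-membered ring carrying an amine in place of the oxygen.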